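This account rests on a few compounds, and the source may have more. Where it says the series, first, only, none or still open, it means among the compounds named here.

Within the data shown here, in a functional assay, read by spectrophotometry, with a stated time of 5 min (on this read-out higher numbers stand for weaker inhibition and lower numbers for stronger inhibition), two compounds sharing the same core have numbers so far. Compound 1 (`COc1cc(/C=C/C(=O)C(=Cc2ccc(O)cc2)C(=O)/C=C/c2ccc(O)c(OC)c2)ccc1O`) gives 48700000 nM. Among the measured compounds shown here, compound 2 (`CCOc1ccc(C=C(C(=O)/C=C/c2ccc(O)c(OC)c2)C(=O)/C=C/c2ccc(O)c(OC)c2)cc1OCC`) gives 73000000 nM, and these two numbers lie within the scatter of each other, so compound 2 stands level with the only other compound measured. Compound 3 (`COc1cc(/C=C/C(=O)C(=Cc2ccccc2)C(=O)/C=C/c2ccc(O)c(OC)c2)ccc1O`) has no number yet. It differs from compound 2 by phenyl in place of 3,4-diethoxyphenyl on a double-bonded chain carbon bound to a double-bonded chain carbon. For the measured compounds named here, one measured step touches the same place, 3,4-diethoxyphenyl in place of 4-hydroxyphenyl, and with a 1.5-fold higher number from compound 1 to compound 2 (0.18 log units; within the scatter) as the only guide, no step beyond the scatter is expected in this assay. Going by the values given here, this is thin evidence, since it is a single step and no compound measured so far carries the plain phenyl. The estimated change is a 1.2-fold lower number from compound 2 to compound 3 (0.09 log units; within the scatter). Compound 3 is expected at 60000000 nM, with an estimated range from 28000000 nM to 130000000 nM.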

Compound 3, half-maximal inhibitory concentration: 84400000 nM
Compound 3: middle estimate off by 1.4-fold (0.15 log units), on the low side; measured number inside the range.
By their numbers in this assay, from the lowest: compounds 1, 2 and 3 (each within the scatter of the next).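

In this assay, phenyl in place of 3,4-diethoxyphenyl on a double-bonded chain carbon bound to a double-bonded chain carbon gives a 1.2-fold higher number from compound 2 to compound 3 (0.06 log units; within the scatter), so a bare aromatic ring with no hydrogen-bond acceptors at this place stands level with the larger 3,4-diethoxyphenyl group. Hydrogen in place of hydroxy on an aromatic carbon gives a 1.7-fold higher number from compound 1 to compound 3 (0.24 log units; within the scatter), which shows that the hydroxy group of compound 1 can also be lost without a step beyond the scatter, and none of the three compounds goes against this flat picture at this position. No measurement is at hand that would explain why the numbers stay level here.

As far as these compounds go, all three compounds carry a six-membered aromatic ring of carbon at this place and share the rest of the core, so it remains open whether an amine, a carboxylic acid or a longer chain such as butoxy on that ring would give a step beyond the scatter. From the compounds shown here alone, it also remains open whether replacing the aromatic ring with a small alkyl group, or changing the other parts of the shared core, would move the number at all.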